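The compounds below may be only part of what the source reports. "The series", "measured", "known", "first", "only" and "open" are said of these compounds alone.

Values so far in a functional assay on MCF7 cells (Homo sapiens) for inhibition, read by sulforhodamine B assay, with a stated time of 48 h; a lower number here means a stronger inhibitor of growth, a higher number a weaker inhibitor of growth:
- compound 1 `COc1ccc(-c2cc(/C=C/C(=O)c3ccc(N)cc3)[nH]n2)cc1`: 3840 nM
- compound 2 `COc1cc(-c2cc(/C=C/C(=O)c3ccc(N)cc3)[nH]n2)cc(OC)c1OC`: 5420 nM
- compound 3 `COc1ccc(C(=O)/C=C/c2cc(-c3cc(OC)c(OC)c(OC)c3)n[nH]2)cc1OC`: 1950 nM
- compound 4 `COc1ccc(C(=O)/C=C/c2cc(-c3cc(OC)c(OC)c(OC)c3)n[nH]2)cc1`: not yet measured

Compound 2, at 5420 nM, lies within the scatter of compound 1, at 3840 nM. Compound 3 lies on the lower side of compound 2, beyond the scatter.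

The change to follow is methoxy in place of amino on an aromatic carbon. In words, this is methoxy in place of amino on an aromatic carbon, para to a large group, or 4-aminophenyl to 4-methoxyphenyl.

Among the compounds with values here, only one measured step bears on it: a 2.8-fold lower number from compound 2 to compound 3 (0.44 log units; beyond the scatter), with 3,4-dimethoxyphenyl in place of 4-aminophenyl on a carbonyl carbon. That step replaces the same 4-aminophenyl, and its group contains the 4-methoxyphenyl pattern. A modest move to a lower number in this assay is therefore expected, though a single step is thin support. The expected change is a 2.1-fold lower number from compound 2 to compound 4 (0.32 log units; beyond the scatter). For compound 4 the estimated value is 2600 nM, with an expected range of 1200 nM to 5200 nM.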

Compound 4, concentration for total growth inhibition: 2960 nM
The estimate for compound 4 lay 1.1-fold (0.06 log units) below the measured number; the range from low to high includes it.
By their numbers in this assay, from the lowest: compounds 3, 4, 1 and 2 (each within the scatter of the next, the first and the last beyond it).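

In this assay, methoxy in place of amino on this aromatic carbon, taken alone, stays within the scatter (a 1.8-fold lower number from compound 2 to compound 4 (0.26 log units; within the scatter)). The further methoxy of the 3,4-dimethoxyphenyl group also stays within the scatter (a 1.5-fold higher number from compound 3 to compound 4 (0.18 log units; within the scatter)), so the earlier step beyond the scatter (a 2.8-fold lower number from compound 2 to compound 3 (0.44 log units; beyond the scatter)) cannot be assigned to either change alone and is seen only when the two are combined. No measurement here accounts for the size of these steps.

On these data alone, whether a hydroxyl group or a dimethylamino group at this place would give a step beyond the scatter remains open. Also open is whether methoxy in place of amino reads the same on the core of compound 1, where only the 4-aminophenyl form is shown.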